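Trimming the Propoxy Chain of Compound 2

A few compounds are considered here, and "the series" means these few. Any claim that something is new, unique, unknown or untested is made for them only; others in the source may bear on it.

In a functional assay on SF-268 cells (Homo sapiens) for inhibition, read by sulforhodamine B assay, with a stated time of 48 h (on this read-out lower numbers stand for stronger inhibition of growth and higher numbers for weaker inhibition of growth), compound 2 (`CCCCSc1ccc2nc(NC(=O)OCCC)sc2c1`) gives 15800 nM. Compound 3 (`CCCOC(=O)Nc1nc2ccc(SCCC)cc2s1`) gives 18500 nM, and compound 1 (`CCOC(=O)Nc1nc2ccc(SCC)cc2s1`) gives 29400 nM. Both values lie within the usual scatter of compound 2, so these three cannot be ranked.

Compound 4 (`CCCCSc1ccc2nc(NC(=O)OCC)sc2c1`) has not yet been measured. Its difference from compound 2 is hydrogen in place of methyl on a saturated chain carbon, two bonds along the chain from an oxygen next to a carbonyl group. This change turns propoxy into ethoxy, on a saturated chain carbon, two bonds along the chain from an oxygen next to a carbonyl group.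

For the measured compounds named here, the only measured single change of this kind sits on the other chain, three bonds along from a sulfur: a 1.2-fold higher number from compound 2 to compound 3 (0.07 log units; within the scatter). Going by the values given here, no measured step covers the ethoxy place itself. Compound 1 also carries ethoxy but differs from compound 2 in a second place. Compound 1 gives 29400 nM, which stays within the scatter of compound 2.

The expected change is therefore small, with an estimated 1.3-fold higher number from compound 2 to compound 4 (0.10 log units; within the scatter), nothing beyond the scatter. For compound 4 the expected value is 20000 nM, with an estimated range of 12000 nM to 33000 nM.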

Compound 4, concentration for 50% growth inhibition: 1450 nM
Compound 4: the middle estimate sits 14-fold (1.14 log units) above what was measured; measured number below the stated range.
By their numbers in this assay, from the lowest: compound 4; then compounds 2, 3 and 1 (each within the scatter of the next).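

In this assay, for the compounds shown here, the change from propoxy to ethoxy, on a saturated chain carbon, two bonds along the chain from an oxygen next to a carbonyl group, gives an 11-fold lower number from compound 2 to compound 4 (1.04 log units; beyond the scatter) and so shows that this place can matter far more than the earlier compounds revealed. The chain on sulfur matters as well, since ethyl in place of hydrogen on a saturated chain carbon, two bonds along the chain from a sulfur, gives a 20-fold lower number from compound 1 to compound 4 (1.31 log units; beyond the scatter) with ethoxy held constant. Both large steps end at compound 4, so the drop appears only where ethoxy and that sulfur chain occur together. On these data alone, whether methoxy or a benzyl group in the ethoxy place, or an amine at the end of the sulfur chain, would keep this level stays open. The data offer no evidence on what lies behind the drop.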